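Urea Heterocycle Swap on a Piperazine Aryl Ether Series

A few compounds are considered here, and "the series" means these few. Any claim that something is new, unique, unknown or untested is made for them only; others in the source may bear on it.

Measured compounds:
compound 1, `O=C(Nc1noc2cnccc12)N1CCN(Cc2cccc(Oc3ccc(Cl)cc3)c2)CC1`: 0.5 nM
compound 2, `O=C(Nc1ccn2ccnc2c1)N1CCN(Cc2cccc(Oc3ccc(Cl)cc3)c2)CC1`: 33 nM

In an assay on isolated protein for inhibition of Fatty-acid amide hydrolase 1 (Homo sapiens), with a stated time of 60 min (a higher number here means a weaker inhibitor, a lower number a stronger inhibitor), compound 1 gives 0.5 nM, the lowest number of the two measured compounds; its nearest neighbour is compound 2 at 33 nM, which is a 66-fold higher number from compound 1 to compound 2 (1.82 log units; beyond the scatter). Compound 3, `O=C(Nc1cccc2nccn12)N1CCN(Cc2cccc(Oc3ccc(Cl)cc3)c2)CC1`, is not yet measured. It differs from compound 1 by a group of 9 heavy atoms (7 carbon, 2 nitrogen; one five-membered aromatic ring with 2 hetero atoms, one six-membered aromatic ring with 1 hetero atom) in place of a group of 9 heavy atoms (6 carbon, 2 nitrogen, 1 oxygen; one five-membered aromatic ring with 2 hetero atoms, one six-membered aromatic ring with 1 hetero atom), on an amide-type nitrogen. Within the data shown here, the one measured step that bears on this change is the move to compound 2, where a group of the same description entered at the same amide-type nitrogen and gave a 66-fold higher number from compound 1 to compound 2 (1.82 log units; beyond the scatter). Since the group entering compound 3 matches that of compound 2 in its composition and ring make-up, a step of comparable direction and size is expected, weakening the inhibitor, though the exact placement differs and the size is uncertain. Compound 3 is therefore expected to give 30 nM, with a range from 4 nM to 250 nM, which would mean a 60-fold higher number from compound 1 to compound 3 (1.78 log units; beyond the scatter).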

Compound 3, half-maximal inhibitory concentration: 2.7 nM
Estimate against measurement, compound 3: 11-fold (1.05 log units) above; the measured number lies below the stated range.
By their numbers in this assay, from the lowest: compound 1; then compound 3; then compound 2.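

At the amide-type nitrogen, the heavy-atom composition and ring make-up of the entering group do not settle the outcome in this assay: two groups that share that description give different numbers, with a 12-fold lower number from compound 2 to compound 3 (1.09 log units; beyond the scatter). The group that leaves compound 1 still gives the lowest number of the three, but replacing it need not cost as much as the earlier step suggested, since the new result is a 5.4-fold higher number from compound 1 to compound 3 (0.73 log units; beyond the scatter). Nothing available explains why the two groups of matching description differ.

The compounds shown leave open whether a plain phenyl or pyridine ring on the same amide-type nitrogen would give a number as low as these bicyclic groups. They also leave open whether the order of the three groups would hold if the chlorine of the shared core were replaced by a methyl group.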